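Methylated core: a chain on the ring carbon

This account rests on a few compounds, and the source may have more. Where it says the series, first, only, none or still open, it means among the compounds named here.

Measured so far:
compound 1 `Cc1cc2[nH]nc(N)c2c(=O)[nH]1` — 10%
compound 2 `Cc1cc2c(c(N)nn2C)c(=O)[nH]1` — 0%

In an assay on isolated protein for inhibition of protein kinase C zeta type (Homo sapiens), read by mobility shift assay, tested at 30 uM (a higher number here means more inhibition at the concentration tested (going by the name of the read-out), a lower number less inhibition), compound 1 gives 10% and compound 2 gives 0%. Among the compounds with values here, the one measured step, a number 10 percentage points lower from compound 1 to compound 2 (within the scatter), is within the scatter. Compound 2 holds the bottom of the two numbers, but the gap to compound 1 is within the scatter, so the two cannot be told apart on this evidence; both sit near the floor of the read-out.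

Compound 3 `COC(=O)CCc1c(C)[nH]c(=O)c2c(N)nn(C)c12` keeps the core of compound 2 and differs by 2-(methoxycarbonyl)ethyl in place of hydrogen on an aromatic carbon. Within the data shown here, no measured step touches a change of this kind: the only step on record concerns methyl in place of hydrogen on an aromatic nitrogen, and it was within the scatter. There is therefore nothing in the numbers that points to a move in either direction, and a step of a number 5 percentage points higher from compound 2 to compound 3 (within the scatter) is expected, that is, none beyond the scatter. Compound 3 is estimated at 5% in this assay, with a range from 0% to 20%.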

Compound 3, a percentage reported as inhibition, at one concentration (the size of the read-out at that concentration, not a potency): 14%
Beside the measured number, compound 3's estimate is 9 percentage points below it; the measured number falls inside the stated range.
By their numbers in this assay, from the lowest: compounds 2, 1 and 3 (each within the scatter of the next, the first and the last beyond it).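

In this assay, within the data shown here, the chain on the ring carbon gives a number 14 percentage points higher from compound 2 to compound 3 (beyond the scatter) and this is the first step to clear the scatter. The aromatic carbon ortho to a fused ring and ortho to a methyl group thus takes 2-(methoxycarbonyl)ethyl, with its 6 heavy atoms, without any loss in the read-out, although compound 3 at 14% is still a size at one concentration and not a potency. No measurement at hand accounts for the gain.

From the compounds shown here alone, whether the gain follows the ester or the chain alone stays open: a carboxylic acid or a primary amide at the end of the chain, a shorter or longer chain, or an amine on the same carbon would separate these readings. Also open, going by these compounds, is whether the same chain gives a step of this kind on the core of compound 1, which carries hydrogen in place of methyl on the aromatic nitrogen.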